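A few compounds are considered here, and "the series" means these few. Any claim that something is new, unique, unknown or untested is made for them only; others in the source may bear on it.

Measured in a physicochemical assay for solubility, read by spectrophotometry, using the shake flask method, with a stated time of 2 days, at pH 6.5; on this read-out lower numbers stand for lower solubility and higher numbers for higher solubility:
Compound 1 `O=C(O)COc1ccc2nc(-c3cn(-c4ccc(O)cc4)nn3)ccc2c1`: 365 ug/mL
Compound 2 `Oc1ccc(-n2cc(-c3ccc4cc(OCC5CCCCO5)ccc4n3)nn2)cc1`: 3.4 ug/mL

Of these two, compound 1 stands highest, at 365 ug/mL. Compound 3 `O=C(O)COc1ccc2nc(-c3cn(-c4ccc(O)c(F)c4)nn3)ccc2c1` has not yet been measured. It differs from compound 1 by a single change, (fluoro in place of hydrogen on an aromatic carbon), which turns 4-hydroxyphenyl into 3-fluoro-4-hydroxyphenyl and leaves the carboxy group in place.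

Among the measured compounds shown here, only one measured step is available: a 110-fold lower number from compound 1 to compound 2 (2.03 log units; beyond the scatter), a large step beyond the scatter. It puts oxan-2-yl in place of carboxy on a saturated chain carbon, so it shows that this assay can move strongly in this set, but it concerns a different place. For the measured compounds named here, no measured pair shows fluoro in place of hydrogen on an aromatic carbon, so the size of this step rests on little evidence.

Starting from compound 1 at 365 ug/mL, only a small move is expected, with a slight lean towards a lower number. The estimated change is a 1.3-fold lower number from compound 1 to compound 3 (0.12 log units; within the scatter), which is expected to stay within the scatter. For compound 3 the estimated value is 280 ug/mL, with an expected range from 120 ug/mL to 550 ug/mL.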

Compound 3, solubility: 37 ug/mL
Compound 3: the middle estimate sits 7.6-fold (0.88 log units) above what was measured; measured number outside the range, below it.
By their numbers in this assay, from the lowest: compound 2; then compound 3; then compound 1.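

In this assay, a single fluoro in place of hydrogen, on an aromatic carbon ortho to a hydroxy group, gives a 9.9-fold lower number from compound 1 to compound 3 (0.99 log units; beyond the scatter), so this change of 4-hydroxyphenyl to 3-fluoro-4-hydroxyphenyl moves the read-out beyond the scatter. The earlier pair showed movement only at the other end of the molecule, where a 110-fold lower number from compound 1 to compound 2 (2.03 log units; beyond the scatter) came with oxan-2-yl in place of carboxy; the new pair shows that the read-out also responds at this aromatic position, with the carboxy group left in place and a change of just one heavy atom. No measurement at hand offers an explanation for the size of this step.

The compounds shown leave open whether this step belongs to fluoro itself or would also appear with chloro or a methyl group on the same aromatic carbon. They also leave open whether fluoro at this position would move the number in the same direction and by a similar amount if oxan-2-yl or an amine stood in place of the carboxy group.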